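Adenosine A3 Binding: From Methylamino Acid to Chlorobenzyl Analogue

The source may hold more compounds than are shown below. What is called first, only, known or untested is meant among the compounds shown, and "the series" means these compounds.

Measured so far:
Compound 1, `CCOC(=O)c1cnc(N2CCCCC2)n2nc(-c3ccco3)nc12`, gives 1770 nM.
Compound 2, `CNc1ncc(C(=O)O)c2nc(-c3ccco3)nn12`, gives 15900 nM.

These numbers come from an assay on CHO cells for displacement of a labelled ligand from adenosine receptor A3 (Homo sapiens); on this read-out higher numbers stand for weaker inhibition and lower numbers for stronger inhibition. Of the two measured compounds, compound 2 gives the higher number, and its gap to compound 1 lies beyond the usual scatter, so compound 2 is the weaker binder of the pair. The two compounds differ in more than one place, so no single change can be read from their values.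

Compound 3, `O=C(O)c1cnc(NCc2ccc(Cl)cc2)n2nc(-c3ccco3)nc12`, carries the change (4-chlorophenyl in place of hydrogen on a saturated chain carbon bound to a nitrogen on an aromatic ring). Compound 1, whose nitrogen bears a larger ring rather than a methyl, gives a lower number than compound 2, and this is the only hint available. The step is expected to lower the number noticeably, a 27-fold lower number from compound 2 to compound 3 (1.42 log units; beyond the scatter), in the direction of stronger binding. Compound 3 is therefore estimated at 600 nM, with a likely range from 100 nM to 4000 nM.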

Compound 3, inhibition constant: 11600 nM
For compound 3 the middle estimate is 19-fold (1.29 log units) below the measured one; measured number outside the range, above it.
By their numbers in this assay, from the lowest: compound 1; then compounds 3 and 2 (each within the scatter of the next).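

In this assay the exchange of methyl for 4-chlorobenzyl, that is 4-chlorophenyl in place of hydrogen on a saturated chain carbon bound to a nitrogen on an aromatic ring, comes to a 1.4-fold lower number from compound 2 to compound 3 (0.14 log units; within the scatter) and lies within the scatter. At this position, with the carboxylic acid kept in both compounds, a much larger group carrying an aromatic ring therefore cannot be told apart from the small methyl, something the earlier pair, which differed in more than one place, could not show. Nothing measured here offers an explanation for this result. As far as these compounds go, whether a plain benzyl without the chlorine, or a longer chain such as 2-phenylethyl, would give a number clearly apart from these two stays open. Also open, from the compounds shown here alone, is whether 4-chlorobenzyl gives a similar reading when an ethyl ester stands in place of the carboxylic acid.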